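A 4-propylphenyl swap on compound 1

A few compounds are considered here, and "the series" means these few. Any claim that something is new, unique, unknown or untested is made for them only; others in the source may bear on it.

For the measured compounds named here, in a functional assay on ECa-109 cells for inhibition, with ECa-109 cell line (Homo sapiens) as the target, read by sulforhodamine B assay (on this read-out higher numbers stand for weaker inhibition and lower numbers for stronger inhibition), compound 1 `Cc1ccc(NC2=CC(=O)c3c(nc4n3[C@H]3OC[C@@H](O)[C@H]3OC4)C2=O)cc1C` gives 4090 nM, the only true number in this small set. Compound 2 `O=C1C(N2CCCC2)=CC(=O)c2c1nc1n2[C@H]2OC[C@@H](O)[C@H]2OC1` reads > 16000 nM, which is a limit of the assay. Compound 3 `O=C1C(N2CCC2)=CC(=O)c2c1nc1n2[C@H]2OC[C@@H](O)[C@H]2OC1` reads > 16000 nM, also a limit. Compound 4 `CCCc1ccc(NC2=CC(=O)c3c(nc4n3[C@H]3OC[C@@H](O)[C@H]3OC4)C2=O)cc1` keeps the core of compound 1 and differs by 4-propylphenyl in place of 3,4-dimethylphenyl on an amine nitrogen. The nearest measured changes are an at least 3.9-fold higher number from compound 1 to compound 2 (0.59 log units; beyond the scatter) and an at least 3.9-fold higher number from compound 1 to compound 3 (0.59 log units; beyond the scatter). Both remove the aromatic ring, which compound 4 retains, so neither tests this swap directly. The expected change is therefore none beyond the scatter, an estimated 1.2-fold lower number from compound 1 to compound 4 (0.07 log units; within the scatter). Compound 4 is expected at 3500 nM, with an estimated range of 1300 nM to 10000 nM.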

Compound 4, half-maximal inhibitory concentration: > 4000 nM
Compound 4 was reported as a limit; the forecaster's own chance of this, stated with the estimate: 10%; at least 1.1-fold (0.05 log units) between middle value and limit.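

Compound 4 reads > 4000 nM, which is a limit, and the step from compound 1 to compound 4 cannot be read. Going by these compounds, whether 4-propylphenyl in place of 3,4-dimethylphenyl on an amine nitrogen changes the result in this assay stays open.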